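This account rests on a few compounds, and the source may have more. Where it says the series, first, only, none or still open, it means among the compounds named here.

The values in a functional assay on MDA-MB-231 cells (Homo sapiens), read by microscopy and transwell migration, with a stated time of 24 h (on this read-out higher numbers stand for weaker inhibition and lower numbers for stronger inhibition), are these:
- compound 1 `COc1cccc(C(=O)Nc2nc(-c3cc(OC)c(OC)c(OC)c3)cs2)c1` with 14000 nM
- compound 2 `COc1ccc(C(=O)N(C)c2nc(-c3cc(OC)c(OC)c(OC)c3)cs2)cc1OC` with > 25000 nM (a limit, not a number)
- compound 3 `COc1cc(-c2csc(N(C)C(=O)c3cccc(OC)c3OC)n2)cc(OC)c1OC` with 108 nM

Compound 3 has the lower of the two true numbers, and compound 1 lies beyond the scatter above it. Compound 4 `COc1cccc(C(=O)N(C)c2nc(-c3cc(OC)c(OC)c(OC)c3)cs2)c1` differs from compound 3 by hydrogen in place of methoxy on an aromatic carbon, ortho to a large group and ortho to a methoxy group hydrogen in place of methoxy on an aromatic carbon and so turns 2,3-dimethoxyphenyl into 3-methoxyphenyl.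

Going by the values given here, only one measured step bears on this change: 2,3-dimethoxyphenyl in place of 3,4-dimethoxyphenyl on a carbonyl carbon gave an at least 230-fold lower number from compound 2 to compound 3 (2.36 log units; beyond the scatter) and is large. The low number thus goes with the 2,3-dimethoxyphenyl group in this single pair. Compound 1 also carries 3-methoxyphenyl and gives 14000 nM in this assay so a large step toward a higher number is expected for compound 4. The expected change is a 23-fold higher number from compound 3 to compound 4 (1.36 log units; beyond the scatter) and it would lie beyond the scatter. For compound 4 the estimate is 2500 nM with 300 nM to 18000 nM as the expected range.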

Compound 4, half-maximal inhibitory concentration: 646 nM
Beside the measured number, compound 4's estimate is 3.9-fold (0.59 log units) above it; low and high end bracket the measured number.
By their numbers in this assay, from the lowest: compound 3; then compound 4; then compound 1. At a limit, above all of these: compound 2.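

In this assay, hydrogen in place of methoxy at this position gives a 6.0-fold higher number from compound 3 to compound 4 (0.78 log units; beyond the scatter) and is modest, so the low number of compound 3 does not depend on this methoxy group alone. The pair that isolates the methyl on the amide-type nitrogen shows a larger step than this one: methyl in place of the amide hydrogen gives a 22-fold lower number from compound 1 to compound 4 (1.34 log units; beyond the scatter) and so ties much of the low number to that methyl group. Taking the other methoxy group off the 3,4-dimethoxyphenyl group gives an at least 38-fold lower number from compound 2 to compound 4 (1.58 log units; beyond the scatter) and rests on a limit, not a number: the limit of > 25000 nM in this assay, at which 1 of the 4 values shown sits.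

The compounds shown leave open how this position behaves with a group other than methoxy or hydrogen, such as hydroxyl, fluorine or an amine. They also leave open whether an ethyl group or a longer chain on the amide nitrogen would serve as the methyl does.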